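Swapping Chloro for Fluoro on a Shared Core

This account rests on a few compounds, and the source may have more. Where it says the series, first, only, none or still open, it means among the compounds named here.

Of the compounds shown here, three built on one shared core have been tested in a functional assay on A549 cells (Homo sapiens) for cytotoxicity, read by MTT assay, with a stated time of 48 h; a higher number here means a weaker inhibitor, a lower number a stronger inhibitor. Compound 1 `Cc1ccc(Cn2c(/C=C3\SC(=S)N(CC(=O)O)C3=O)nc3cc(Cl)ccc32)cc1` gives 38600 nM in this assay. Compound 3 `Cc1ccc(Cn2c(/C=C3\SC(=S)N(CC(=O)O)C3=O)nc3cc(F)ccc32)cc1` carries fluoro in place of chloro on an aromatic carbon, and in this assay compound 3 gives 13800 nM, so that single change made a 2.8-fold lower number from compound 1 to compound 3 (0.45 log units; beyond the scatter). Compound 2 `Cc1ccc(Cn2c(/C=C3\SC(=S)N(CC(=O)O)C3=O)nc3ccc(Cl)cc32)cc1` has the same atoms as compound 1 joined differently; the difference between the two cores is not broken down here. In this assay compound 2 gives 9970 nM, the lowest of the three numbers, although its gap to compound 3 lies within the scatter, so no order can be claimed between those two.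

Compound 4 `Cc1ccc(Cn2c(/C=C3\SC(=S)N(CC(=O)O)C3=O)nc3ccc(F)cc32)cc1` has not yet been measured. It carries fluoro in place of chloro on an aromatic carbon on the core of compound 2, the same change that turned compound 1 into compound 3, at the same kind of place. Among the measured compounds shown here, that earlier example, a 2.8-fold lower number from compound 1 to compound 3 (0.45 log units; beyond the scatter), is the only guide available, and one example is a thin base on which the size of the step could easily shift. For compound 4 the expected step is therefore a 2.2-fold lower number from compound 2 to compound 4 (0.35 log units; beyond the scatter), somewhat smaller than the earlier one to allow for that uncertainty. On that basis compound 4 is estimated to give about 4500 nM in this assay, with a likely range from 1800 nM to 11000 nM.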

Compound 4, half-maximal inhibitory concentration: 9640 nM
For compound 4 the middle estimate is 2.1-fold (0.33 log units) below the measured one; low and high end bracket the measured number.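

Fluoro in place of chloro did not repeat its earlier result on the second core: in this assay the swap gave a 1.0-fold lower number from compound 2 to compound 4 (0.01 log units; within the scatter), so on this core no change can be read from it at all. Among the compounds shown here, the step measured on one core therefore did not carry over at the same size to the other, and the two steps are truly different rather than two noisy readings of one effect: the same change on two cores in this assay, a 2.8-fold lower number (0.45 log units; beyond the scatter) from compound 1 to compound 3 and a 1.0-fold lower number (0.01 log units; within the scatter) from compound 2 to compound 4, 2.7-fold (0.43 log units) apart, beyond the scatter of two such steps This shows that, within this series, the size of the swap depends on the core that carries it, but it rests on only two pairs of compounds, so it cannot say which result is more typical, and the data do not explain why the two cores part ways.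

The compounds shown leave open how a bromo, a methyl or an amine on the same aromatic carbon would read on either core, since only chloro and fluoro appear there. They also leave open whether replacing the carboxylic acid with an ester or an amide would alter the numbers, and whether the difference between the two cores would persist with such groups in place.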